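Cyclohexyl for phenyl on the amide nitrogen of a trisulfate

This account rests on a few compounds, and the source may have more. Where it says the series, first, only, none or still open, it means among the compounds named here.

Compound 1 `CO[C@H]1O[C@H](CNC(=O)CN(Cc2ccccc2)C(C)=O)[C@@H](OS(=O)(=O)O)[C@H](OS(=O)(=O)O)[C@@H]1OS(=O)(=O)O` — 140000 nM
Compound 2 `CO[C@H]1O[C@H](CNC(=O)CN(CCOS(=O)(=O)O)C(C)=O)[C@@H](OS(=O)(=O)O)[C@H](OS(=O)(=O)O)[C@@H]1OS(=O)(=O)O` — 95000 nM
Compound 3 `CO[C@H]1O[C@H](CNC(=O)CN(C(C)=O)c2ccccc2)[C@@H](OS(=O)(=O)O)[C@H](OS(=O)(=O)O)[C@@H]1OS(=O)(=O)O` — 196000 nM

All three were read in an assay on isolated protein for binding affinity to fibroblast growth factor 1 (Homo sapiens), read by surface plasmon resonance; a higher number here means weaker binding, a lower number tighter binding. Compound 3 sits at the weak end of this small set: against compound 2 the step is a 2.1-fold higher number from compound 2 to compound 3 (0.31 log units; beyond the scatter), whereas against compound 1 the two values lie within the scatter, a 1.4-fold higher number from compound 1 to compound 3 (0.15 log units; within the scatter). Compound 4 `CO[C@H]1O[C@H](CNC(=O)CN(C(C)=O)C2CCCCC2)[C@@H](OS(=O)(=O)O)[C@H](OS(=O)(=O)O)[C@@H]1OS(=O)(=O)O` differs from compound 3 only in cyclohexyl in place of phenyl on an amide-type nitrogen. Among the compounds with values here, no measured step swaps an aromatic ring for a saturated one; the nearest precedents, a 1.4-fold higher number from compound 1 to compound 3 (0.15 log units; within the scatter) and a 1.5-fold lower number from compound 1 to compound 2 (0.17 log units; within the scatter), both fall within the scatter, and only a 2.1-fold higher number from compound 2 to compound 3 (0.31 log units; beyond the scatter) is modest. Compound 4 is therefore expected to give 170000 nM, spanning 80000 nM to 350000 nM, an expected step of a 1.2-fold lower number from compound 3 to compound 4 (0.06 log units; within the scatter).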

Compound 4, dissociation constant: 310000 nM
Estimate against measurement, compound 4: 1.8-fold (0.26 log units) below, and the stated range covers the measured number.
By their numbers in this assay, from the lowest: compounds 2, 1, 3 and 4 (each within the scatter of the next, the first and the last beyond it).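

In this assay the step from phenyl to cyclohexyl on the amide-type nitrogen is a 1.6-fold higher number from compound 3 to compound 4 (0.20 log units; within the scatter) and so shows that, at this position, an aromatic ring and a non-aromatic ring of six carbons are not told apart. Cyclohexyl does stand apart from the other two groups: against benzyl the step is a 2.2-fold higher number from compound 1 to compound 4 (0.35 log units; beyond the scatter) and against 2-(sulfooxy)ethyl it is a 3.3-fold higher number from compound 2 to compound 4 (0.51 log units; beyond the scatter) while phenyl stays within the scatter of benzyl. Nothing at hand explains these numbers.

As far as these compounds go, whether an amine or a carboxylic acid on a longer chain at this nitrogen would give a lower number than 2-(sulfooxy)ethyl remains open.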